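Swapping a Ring Substituent in Compound 1

The source may hold more compounds than are shown below. What is called first, only, known or untested is meant among the compounds shown, and "the series" means these compounds.

compound 1, `Cc1nc(N2CCC(N3C(=O)CCC3=O)CC2)nc2ccc(NC(=O)/C=C/c3ccc(OC(F)(F)F)cc3)cc12`: 35 nM
compound 2, `C/C(=C\C(=O)Nc1ccc2nc(N3CCC(O)(C4CC4)CC3)nc(C)c2c1)c1ccc(Cl)cc1`: 340 nM
compound 3, `COCCC1(O)CCN(c2nc(C)c3cc(NC(=O)/C=C/c4ccc(Cl)cc4)ccc3n2)CC1`: 220 nM

Three compounds sharing a common core were tested in a functional assay on CHO-K1 cells for antagonist activity at melanin-concentrating hormone receptor 1 (Homo sapiens), read by inositol phosphate accumulation, with stated times of 10 min and 45 min; on this read-out lower numbers stand for stronger inhibition and higher numbers for weaker inhibition. Compound 1 gives the lowest number of the three, 35 nM, and is the most potent of them. The nearest of the others is compound 3 with 220 nM, a higher number that lies beyond the scatter of the measurement. Compound 2, at 340 nM, stands furthest away, also beyond the scatter. No two of these compounds differ in just one place, so the numbers do not isolate any single structural feature.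

Compound 4, `Cc1nc(N2CCC(NS(=O)(=O)N(C)C)CC2)nc2ccc(NC(=O)/C=C/c3ccc(OC(F)(F)F)cc3)cc12`, has not yet been measured in this assay. It differs from compound 1 in one place: (dimethylsulfamoyl)amino in place of 2,5-dioxopyrrolidin-1-yl on a saturated ring carbon. The group that leaves and the group that enters have the same count of heavy atoms, but the entering group has no ring and carries a hydrogen-bond donor. Among the compounds with values here, no measured pair here tests this kind of change, so the expectation rests on compound 1 alone. The step of a 1.7-fold higher number from compound 1 to compound 4 (0.23 log units; within the scatter) is expected to be small, a slight rise in the number at most, likely close to or within the scatter. Compound 4 is expected to give about 60 nM, with a range from 15 nM to 250 nM.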

Compound 4, half-maximal inhibitory concentration: 31 nM
Estimate against measurement, compound 4: 1.9-fold (0.29 log units) above; measured number inside the range.
By their numbers in this assay, from the lowest: compounds 4 and 1 (each within the scatter of the next); then compounds 3 and 2 (each within the scatter of the next).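

In this assay, within the data shown here, (dimethylsulfamoyl)amino in place of 2,5-dioxopyrrolidin-1-yl on the saturated ring carbon gives a 1.1-fold lower number from compound 1 to compound 4 (0.05 log units; within the scatter), the only comparison in this set that changes a single place. It shows that at this position, three ring bonds from the ring nitrogen, the five-membered ring of compound 1 is not needed to keep the number in the same range, since an open group of the same heavy-atom count that also carries a hydrogen-bond donor reads the same within the scatter. No measurement at hand offers an explanation for why these two different groups read alike.

The compounds shown leave open whether this holds for groups of another kind on the same ring carbon, such as a free amine, a carboxylic acid or a longer chain ending in a sulfonamide. They also leave open whether the sulfamoyl nitrogen's hydrogen matters at all, which the same group with a methyl on that nitrogen would test, and whether the result carries over to cores bearing a chlorophenyl group in place of the trifluoromethoxy-substituted ring.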